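The source may hold more compounds than are shown below. What is called first, only, known or untested is meant among the compounds shown, and "the series" means these compounds.

In a functional assay on NCI-H460 cells (Homo sapiens) for inhibition, read by sulforhodamine B assay, with a stated time of 72 h (on this read-out higher numbers stand for weaker inhibition and lower numbers for stronger inhibition), compound 1 `CCNC(=O)c1nnn(-c2cc(C(C)C)c(O)cc2O)c1-c1ccc(CN2CCC[C@H](O)C2)cc1` gives 70 nM and belongs to the lower pair of the three numbers, alongside compound 2 `CCNC(=O)c1nnn(-c2cc(C(C)C)c(O)cc2O)c1-c1ccc(CN2CCC[C@@H](O)C2)cc1` at 52 nM as its partner. The two differ only in configuration as drawn the fact that compounds 1 and 2 differ only in the configuration as drawn and the step between them is a 1.3-fold lower number from compound 1 to compound 2 (0.13 log units; within the scatter) in size. Compound 3 `CCNC(=O)c1nnn(-c2cc(C(C)C)c(O)cc2O)c1-c1ccc(CN2CCNCC2)cc1` gives 250 nM as the highest number, with a 3.6-fold higher number from compound 1 to compound 3 (0.55 log units; beyond the scatter) and a 4.8-fold higher number from compound 2 to compound 3 (0.68 log units; beyond the scatter) as its two steps.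

Compound 4 `CCNC(=O)c1nnn(-c2cc(C(C)C)c(O)cc2O)c1-c1ccc(CN2CCC(N(C)C)CC2)cc1` has no number yet. The change is 4-(dimethylamino)piperidin-1-yl in place of 3-hydroxypiperidin-1-yl on a saturated chain carbon bound to an aromatic carbon and it falls on a saturated chain carbon bound to an aromatic carbon, the same place that differs in compound 3. The expectation rests on compound 3, whose step a 3.6-fold higher number from compound 1 to compound 3 (0.55 log units; beyond the scatter) is modest and runs towards weaker inhibition. The group entering in compound 4 is a different one, so a step in the same direction but smaller, close to the scatter, is expected in this assay for now. The expected step is a 1.4-fold higher number from compound 1 to compound 4 (0.15 log units; within the scatter) and it may not clear the scatter. For compound 4 the estimated value is 100 nM with an expected range from 35 nM to 280 nM as the working figures.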

Compound 4, half-maximal inhibitory concentration: 120 nM
The estimate for compound 4 lay 1.2-fold (0.08 log units) below the measured number; the measured number falls inside the stated range.
By their numbers in this assay, from the lowest: compounds 2, 1 and 4 (each within the scatter of the next, the first and the last beyond it); then compound 3.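

In this assay, the saturated chain carbon bound to an aromatic carbon accepts the larger 4-(dimethylamino)piperidin-1-yl, with 9 heavy atoms against 7 in the group it replaces, and the replacement of piperazin-1-yl gives a 2.1-fold lower number from compound 3 to compound 4 (0.32 log units; beyond the scatter). So the weaker inhibition seen for compound 3 does not extend to every nitrogen-containing ring at this place, although two rings are a narrow basis and no trend can be drawn from them. Against the 3-hydroxypiperidin-1-yl compounds, the same change reads as a 1.7-fold higher number from compound 1 to compound 4 (0.23 log units; within the scatter) and as a 2.3-fold higher number from compound 2 to compound 4 (0.36 log units; beyond the scatter), so whether it costs anything depends on the reference, and those two references are one pair of stereoisomers rather than two different groups: the fact that compounds 1 and 2 differ only in the configuration as drawn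

Unsubstituted piperidin-1-yl would help separate the effect of the hydroxyl from that of the ring itself, and the compounds shown do not settle this. On these data alone, how morpholin-4-yl or an open-chain dimethylamino group would read on the same carbon also remains open.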